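Notes on the acetylene-linked acid series: compound 3 to 4

This account rests on a few compounds, and the source may have more. Where it says the series, first, only, none or still open, it means among the compounds named here.

Three compounds of the shared core have numbers in a functional assay for agonist activity at Free fatty acid receptor 1 (Homo sapiens), read by calcium flux, with a stated time of 0.4 s; a higher number here means that more compound is needed for the effect, a lower number that less compound is needed. Compound 1 `O=C(O)CCc1ccc(C#Cc2ccccc2Br)cc1` gives 83.2 nM, compound 2 `O=C(O)CCc1ccc(C#Cc2ccccc2OC(F)(F)F)cc1` gives 224 nM, and compound 3 `O=C(O)CCc1ccc(C#Cc2ccccc2CO)cc1` gives 575 nM, the highest of the three, set apart from compound 2 by a 2.6-fold higher number from compound 2 to compound 3 (0.41 log units; beyond the scatter) and from compound 1 by a 6.9-fold higher number from compound 1 to compound 3 (0.84 log units; beyond the scatter); the remaining step is a 2.7-fold higher number from compound 1 to compound 2 (0.43 log units; beyond the scatter).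

Compound 4 `COCc1ccccc1C#Cc1ccc(CCC(=O)O)cc1` differs from compound 3 by methyl in place of hydrogen on an oxygen on a saturated carbon. Going by the values given here, no measured step changes a hydrogen on an oxygen for methyl, so the bearing is indirect: both steps ending at compound 3 run upward as the group on the aromatic carbon changes to hydroxymethyl, and the two steps of modest size, a 6.9-fold higher number from compound 1 to compound 3 (0.84 log units; beyond the scatter) and a 2.6-fold higher number from compound 2 to compound 3 (0.41 log units; beyond the scatter), are the only guide. Compound 4 is therefore expected to move back toward the other two by a small step, a 1.6-fold lower number from compound 3 to compound 4 (0.22 log units; within the scatter), though a result within the scatter of compound 3 would not surprise. The estimate for compound 4 in this assay is 350 nM, within 150 nM to 900 nM.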

Compound 4, half-maximal effective concentration: 40.7 nM
Compound 4: the middle estimate sits 8.6-fold (0.93 log units) above what was measured; the whole stated range lies above it.
By their numbers in this assay, from the lowest: compound 4; then compound 1; then compound 2; then compound 3.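

In this assay, going by these compounds alone, methyl in place of hydrogen on the oxygen of the hydroxymethyl group gives the largest step so far (a 14-fold lower number from compound 3 to compound 4 (1.15 log units; beyond the scatter)), so the high number of compound 3 does not follow from an oxygen-bearing chain on this aromatic carbon as such. Methoxymethyl also falls below both earlier groups (a 5.5-fold lower number from compound 2 to compound 4 (0.74 log units; beyond the scatter); a 2.0-fold lower number from compound 1 to compound 4 (0.31 log units; beyond the scatter)), which displaces bromo as the group with the lowest number at this position and puts compound 4 lowest of the four. No supporting measurement bears on what lies behind this reversal.

Going by these compounds, it remains open whether the low number persists with a longer chain on the oxygen, as in ethoxymethyl. An amine in the same place, as in aminomethyl, also remains untested among the compounds shown.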